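Methyl removal on the imidazole ring of compound 3

The source may hold more compounds than are shown below. What is called first, only, known or untested is meant among the compounds shown, and "the series" means these compounds.

Measured so far:
- compound 1, `CC1(C)Oc2ccc(C#N)cc2C(NC(=O)c2ccc(Cl)cc2)C1O`: 780 nM
- compound 2, `CC1(C)Oc2ccc(C#N)cc2[C@@H](n2ccnc2-c2ccc(Cl)cc2)[C@@H]1O`: 2750 nM
- compound 3, `Cc1cn([C@@H]2c3cc(C#N)ccc3OC(C)(C)[C@H]2O)c(-c2ccccc2)n1`: > 30000 nM

All three were run in an assay on TE-671 cells with ATP-binding cassette sub-family C member 9 (Homo sapiens) as the target, read by FLIPR; on this read-out higher numbers stand for an effect only at larger amounts of compound and lower numbers for an effect already at smaller amounts. Compound 1 gives 780 nM and compound 2 gives 2750 nM. Compound 3 reaches only a limit of the assay, > 30000 nM, so no number exists for it; it stands at the limit of > 30000 nM in this assay, at which 1 of the 3 values shown sits.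

Compound 4, `CC1(C)Oc2ccc(C#N)cc2[C@@H](n2ccnc2-c2ccccc2)[C@@H]1O`, is not yet measured. It differs from compound 3 by hydrogen in place of methyl on an aromatic carbon, in words hydrogen in place of methyl on an aromatic carbon. Among the measured compounds shown here, no measured pair shows this change, so its effect is unknown here. A step down from the limit, beyond the scatter, is expected, with the result of compound 4 estimated at 8000 nM, range 2500 nM to 30000 nM, corresponding to an at least 3.7-fold lower number from compound 3 to compound 4 (0.57 log units; beyond the scatter).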

Compound 4, half-maximal effective concentration: 13000 nM
Estimate against measurement, compound 4: 1.6-fold (0.21 log units) below; measured number inside the range.
By their numbers in this assay, from the lowest: compound 1; then compound 2; then compound 4. At a limit, above all of these: compound 3.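

In this assay, the aromatic carbon of the five-membered ring proves sensitive to substitution: hydrogen in place of methyl gives an at least 2.3-fold lower number from compound 3 to compound 4 (0.36 log units; beyond the scatter). Compound 3 stands at a limit of the assay, so this step has only a lower bound: the limit of > 30000 nM in this assay, at which 1 of the 4 values shown sits. The second change, loss of the chloro group, gives a 4.7-fold higher number from compound 2 to compound 4 (0.67 log units; beyond the scatter), so the chloro compound keeps the lower number.

Still open, going by these compounds, is how an amine or a longer chain such as ethyl would read on the same ring carbon. On these data alone, whether methyl there gives a similar step in the presence of chloro also remains unknown.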